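Pyridinone for Methoxypyridine on the Sulfonyl Biaryl

The compounds below may be only part of what the source reports. "The series", "measured", "known", "first", "only" and "open" are said of these compounds alone.

Compound 1 `CCCCc1nc(=O)c(S(=O)(=O)c2ccc(-c3ccc(F)cc3)cc2)c(O)n1-c1c(OC)cccc1OC`: 47%
Compound 2 `CCCCc1[nH]c(=O)c(S(=O)(=O)c2ccc(-c3cccnc3OC)cc2)c(O)c1-c1c(OC)cccc1OC`: 24%

In an ADME assay on microsomes from liver (Mus musculus) for metabolic stability, using NADPH, with a stated time of 10 min (a lower number here means that less of the compound is left, a higher number that more of the compound is left), compound 2 gives 24%, the lowest of the two numbers; compound 1 lies higher by a margin beyond the scatter. Compound 3 `CCCCc1[nH]c(=O)c(S(=O)(=O)c2ccc(-n3cc(Cl)ccc3=O)cc2)c(O)c1-c1c(OC)cccc1OC` differs from compound 2 by a group of 8 heavy atoms (5 carbon, 1 nitrogen, 1 oxygen, 1 chlorine; one six-membered aromatic ring with 1 hetero atom) in place of a group of 8 heavy atoms (6 carbon, 1 nitrogen, 1 oxygen; one six-membered aromatic ring with 1 hetero atom), on an aromatic carbon. Within the data shown here, no step between measured compounds mirrors this change, so only compound 2 itself anchors the expectation in this assay: a step of modest size, slightly upward at most, and quite possibly not beyond the scatter. Compound 3 is estimated at 32%, within 15% to 55%. The expected step is thus a number 8 percentage points higher from compound 2 to compound 3 (within the scatter).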

Compound 3, percent of the compound remaining: 64%
The estimate for compound 3 lay 32 percentage points below the measured number, outside the stated range (above it).
By their numbers in this assay, from the lowest: compound 2; then compound 1; then compound 3.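

In this assay, the aromatic carbon para to a large group proves sensitive: the chlorine-bearing group entering for 2-methoxypyridin-3-yl gives a number 40 percentage points higher from compound 2 to compound 3 (beyond the scatter) and so a large step. The two groups match in heavy-atom count, ring size and hydrogen-bond counts, yet the read-out still moves strongly. Nothing measured here bears on the reason for this step.

The compounds shown leave open whether the chlorine or the ring carbonyl carries the step, since both change together. A methyl or trifluoromethyl in place of the chlorine would separate the two.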